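Phenethyl for Methylphenyl on Sulfur: What Compound 3 May Show

The compounds below may be only part of what the source reports. "The series", "measured", "known", "first", "only" and "open" are said of these compounds alone.

Compound 1 `Cc1ccc(SCc2ccc(/C=C/C(=O)Nc3ccccc3N)cc2)cc1` stands highest of the two measured numbers: in a functional assay on A-375 cells (Homo sapiens) for inhibition, read by CCK-8 assay, with a stated time of 72 h, tested at 2 uM (on this read-out higher numbers stand for more inhibition of growth at the one concentration tested and lower numbers for less inhibition of growth), compound 1 gives 22.9%. Compound 2 `COc1ccc(SCc2ccc(C(=O)Nc3ccccc3N)cc2)cc1` sits lower, as in this assay compound 2 gives 10.2%, a gap beyond the usual scatter. Compound 3 `Nc1ccccc1NC(=O)/C=C/c1ccc(CSCCc2ccccc2)cc1` has not yet been measured. It differs from compound 1 in one place: phenethyl in place of 4-methylphenyl on a sulfur. Going by the values given here, no measured pair follows this change, so only a small step is expected in this assay, in either direction or none beyond the scatter. The estimate for compound 3 is 19%, within 5% to 35%. That estimate means an expected step of a number 3.9 percentage points lower from compound 1 to compound 3 (within the scatter).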

Compound 3, percent growth inhibition at one concentration: 41.9%
The estimate for compound 3 lay 22.9 percentage points below the measured number, outside the stated range (above it).
By their numbers in this assay, from the lowest: compound 2; then compound 1; then compound 3.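

In this assay, the group on the sulfur proves able to move the read-out: phenethyl in place of 4-methylphenyl gives a number 19 percentage points higher from compound 1 to compound 3 (beyond the scatter). The two groups carry the same count of six-membered aromatic rings of carbon only and no hydrogen-bond donors or acceptors, so those counts do not separate them. Nothing shown accounts for the step. Still open, on these data alone, is whether a longer chain on the sulfur, or a carboxylic acid at the end of the phenethyl group, would rise beyond compound 3 or fall back.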